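The source may hold more compounds than are shown below. What is called first, only, known or untested is meant among the compounds shown, and "the series" means these compounds.

Values in a functional assay on SEM cells (Homo sapiens) for cytotoxicity, read by MTT assay, with a stated time of 72 h (a higher number here means a weaker inhibitor, a lower number a stronger inhibitor), are as follows
- compound 1 `CCOC(=O)c1sc2ccccc2c1Nc1cc(OC)c(OC)c(OC)c1` gives 1900 nM
- compound 2 `COC(=O)c1sc2ccccc2c1Nc1cc(OC)c(OC)c(OC)c1` gives 179 nM
- compound 3 `COC(=O)c1sc2cccc(C)c2c1Nc1cc(OC)c(OC)c(OC)c1` gives 2510 nM

Compound 2 (179 nM) holds the lowest number of the three, and its gaps to both others lie beyond the scatter. Compound 4 (`COC(=O)c1sc2ccc(C)cc2c1Nc1cc(OC)c(OC)c(OC)c1`) differs from it by a single exchange (methyl in place of hydrogen on an aromatic carbon), methyl in place of hydrogen on an aromatic carbon. Compound 3 (2510 nM) carries such a methyl on another aromatic carbon, and that step (a 14-fold higher number from compound 2 to compound 3 (1.15 log units; beyond the scatter)) was large and upward. The other measured step (an 11-fold lower number from compound 1 to compound 2 (1.03 log units; beyond the scatter)) was also large, but it lies on a saturated chain carbon and bears only indirectly. A higher number is expected, likely by a smaller margin than that measured rise (a 3.1-fold higher number from compound 2 to compound 4 (0.49 log units; beyond the scatter)). Compound 4 is estimated at 550 nM in this assay (expected range 130 nM to 2500 nM).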

Compound 4, half-maximal inhibitory concentration: 185 nM
Compound 4: middle estimate off by 3.0-fold (0.47 log units), on the high side; low and high end bracket the measured number.
By their numbers in this assay, from the lowest: compounds 2 and 4 (each within the scatter of the next); then compounds 1 and 3 (each within the scatter of the next).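

In this assay, methyl in place of hydrogen on this aromatic carbon, meta to a fused ring and para to a fused ring, leaves the number within the scatter (a 1.0-fold higher number from compound 2 to compound 4 (0.01 log units; within the scatter)). The same exchange on another aromatic carbon gave a large rise (a 14-fold higher number from compound 2 to compound 3 (1.15 log units; beyond the scatter)), so among these compounds the outcome of adding methyl depends on the carbon that carries it. Nothing available here accounts for this difference. From the compounds shown here alone, whether an amine, a chlorine or a longer chain would be tolerated on this carbon remains open.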